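Aryl substituent change from compound 3 to compound 4

The source may hold more compounds than are shown below. What is called first, only, known or untested is meant among the compounds shown, and "the series" means these compounds.

Measured compounds:
compound 1 `O=C1O[C@H]([C@@H](O)Cn2cc(-c3cccc(O)c3)nn2)C(OCc2ccccc2)=C1OCc1ccccc1` — 39300 nM
compound 2 `COc1ccc(-c2cn(C[C@H](O)[C@H]3OC(=O)C(OCc4ccccc4)=C3OCc3ccccc3)nn2)cc1` — 16400 nM
compound 3 `Cc1ccc(-c2cn(C[C@H](O)[C@H]3OC(=O)C(OCc4ccccc4)=C3OCc3ccccc3)nn2)cc1` — 25500 nM

All three numbers come from a functional assay on HeLa cells (Homo sapiens) for antiproliferative activity, read by MTT assay, with a stated time of 72 h; on this read-out lower numbers stand for stronger inhibition and higher numbers for weaker inhibition. Compound 3 holds the second highest of the three numbers; its nearest neighbour is compound 1, at a 1.5-fold lower number from compound 1 to compound 3 (0.19 log units; within the scatter), and its furthest is compound 2, at a 1.6-fold higher number from compound 2 to compound 3 (0.19 log units; within the scatter), so compound 3 is not separated from either by more than the scatter. Going by the values given here, the only step that reaches beyond the scatter in this set is a 2.4-fold lower number from compound 1 to compound 2 (0.38 log units; beyond the scatter), a modest one.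

Compound 4 `O=C1O[C@H]([C@@H](O)Cn2cc(-c3ccc(Br)cc3)nn2)C(OCc2ccccc2)=C1OCc1ccccc1` differs from compound 3 by bromo in place of methyl on an aromatic carbon. Among the compounds with values here, no measured compound carries bromo, so the step that bears most directly is the one between the two 4-substituted phenyl groups, a 1.6-fold higher number from compound 2 to compound 3 (0.19 log units; within the scatter), which stays within the scatter; the step of a 1.5-fold lower number from compound 1 to compound 3 (0.19 log units; within the scatter) also stays within it. Swaps of the substituent on this phenyl ring have so far moved the number little, and a bromo in this place is therefore expected to give no step beyond the scatter in this assay , written as a 1.2-fold lower number from compound 3 to compound 4 (0.06 log units; within the scatter).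

For compound 4 the estimate in this assay is 22000 nM, with a range from 9000 nM to 55000 nM.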

Compound 4, half-maximal inhibitory concentration: 3910 nM
Compound 4: the middle estimate sits 5.6-fold (0.75 log units) above what was measured; the whole stated range lies above it.
By their numbers in this assay, from the lowest: compound 4; then compounds 2, 3 and 1 (each within the scatter of the next, the first and the last beyond it).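

In this assay the largest step among compound 1, compound 2 and compound 3 had been a 2.4-fold lower number from compound 1 to compound 2 (0.38 log units; beyond the scatter), but the substituent para to a large group proves able to move the number much further: bromo in place of methyl gives a 6.5-fold lower number from compound 3 to compound 4 (0.81 log units; beyond the scatter), and bromo in place of methoxy gives a 4.2-fold lower number from compound 2 to compound 4 (0.62 log units; beyond the scatter). Set against the 3-hydroxyphenyl group, the 4-bromophenyl group gives a 10-fold lower number from compound 1 to compound 4 (1.00 log units; beyond the scatter), and with all three of its steps beyond the scatter, compound 4 is the strongest of the four in this series. Nothing at hand accounts for the gain from this one substituent change.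

As far as these compounds go, it remains open whether chloro, iodo or trifluoromethyl on the same aromatic carbon would match bromo, or whether the gain is particular to bromo. Equally open, from the compounds shown here alone, are how an amine or a carboxylic acid at this place would read in this assay and whether bromo would keep its gain on another carbon of the phenyl ring.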